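Working notes: trifluoromethoxy to butyl on the sulfonyl ring

This account rests on a few compounds, and the source may have more. Where it says the series, first, only, none or still open, it means among the compounds named here.

compound 1 `O=C(/C=C/c1ccccc1)c1ccc(N2CCN(S(=O)(=O)c3ccccc3)CC2)cc1`: 30%
compound 2 `O=C(/C=C/c1ccccc1)c1ccc(N2CCN(S(=O)(=O)c3ccc(OC(F)(F)F)cc3)CC2)cc1`: 47.4%

Going by the values given here, in a functional assay on the whole organism (strain Kunming) for inhibition, with Mus musculus as the target, with a stated time of 1 h, at a dose of 40 mg/kg by the oral route (a lower number here means less inhibition, a higher number more inhibition at the dose given (going by the name of the read-out)), compound 1 gives 30% and compound 2 gives 47.4%, the higher of the two numbers; the one measured step is a number 17.4 percentage points higher from compound 1 to compound 2 (beyond the scatter). Compound 3 `CCCCc1ccc(S(=O)(=O)N2CCN(c3ccc(C(=O)/C=C/c4ccccc4)cc3)CC2)cc1` differs from compound 2 by butyl in place of trifluoromethoxy on an aromatic carbon. Among the compounds with values here, no measured step exchanges one group for another at this aromatic carbon, so only the single step from hydrogen to trifluoromethoxy bears on it, and only loosely. The expected step is a number 5.4 percentage points lower from compound 2 to compound 3 (within the scatter), within the scatter. Compound 3 is estimated at 42%, between 25% and 60%.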

Compound 3, a percentage reported as inhibition, in the whole organism at one dose (the size of the read-out at that dose, not a potency): 24%
Estimate against measurement, compound 3: 18 percentage points above; measured number outside the range, below it.
By their numbers in this assay, from the lowest: compounds 3 and 1 (each within the scatter of the next); then compound 2.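

In this assay the rise seen with trifluoromethoxy does not carry over to butyl: the read-out is a number 23.4 percentage points lower from compound 2 to compound 3 (beyond the scatter), and against hydrogen it is a number 6 percentage points lower from compound 1 to compound 3 (within the scatter). Butyl is therefore not separated from hydrogen at this aromatic carbon, and among these three groups only trifluoromethoxy stands apart. No available data account for this difference.

Open, as far as these compounds go, is whether the rise depends on the oxygen or on the fluorines, which a methoxy or a trifluoromethyl group at this carbon would test. Also open, from the compounds shown here alone, is how an amine or a carboxylic acid here would read.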